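One Added Chloro on Two Related Cores

The compounds below may be only part of what the source reports. "The series", "measured", "known", "first", "only" and "open" are said of these compounds alone.

Measured compounds:
Compound 1, `ClCc1cccc(Cn2cnc3ncnc(Cl)c32)c1`, in a functional assay on NCI-H460 cells (Homo sapiens) for cytotoxicity, read by sulforhodamine B assay, with a stated time of 48 h (a higher number here means a weaker inhibitor of growth, a lower number a stronger inhibitor of growth), gives 4460 nM.
Compound 2, `ClCc1ccccc1Cn1cnc2ncnc(Cl)c21`, in this assay gives 60300 nM.
Compound 3, `ClCc1cccc(Cn2cnc3nc(Cl)nc(Cl)c32)c1`, in this assay gives 3090 nM.

Compound 1 and compound 2 are built from the same atoms joined differently; the difference between the two cores is not broken down here. In this assay compound 2 stands highest of the three, with compound 1 nearest and compound 3 furthest, both well beyond the scatter. From compound 1 to compound 3 the change is chloro in place of hydrogen on an aromatic carbon, and it made a step of a 1.4-fold lower number from compound 1 to compound 3 (0.16 log units; within the scatter).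

Compound 4, `ClCc1ccccc1Cn1cnc2nc(Cl)nc(Cl)c21`, has not yet been measured. It differs from compound 2 by chloro in place of hydrogen on an aromatic carbon, the same kind of change as from compound 1 to compound 3, at a place described in the same words. Since the earlier step lay within the scatter, a step of about a 1.4-fold lower number from compound 2 to compound 4 (0.15 log units; within the scatter) is expected, resting on a 1.4-fold lower number from compound 1 to compound 3 (0.16 log units; within the scatter) and on the value of compound 2, 60300 nM. Compound 4 is therefore estimated at 43000 nM, likely between 15000 nM and 120000 nM.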

Compound 4, concentration for total growth inhibition: 5880 nM
Estimate against measurement, compound 4: 7.3-fold (0.86 log units) above; measured number outside the range, below it.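

In this assay, chloro in place of hydrogen on an aromatic carbon, between two ring nitrogen atoms, gave a large step on the core of compound 2, a 10-fold lower number from compound 2 to compound 4 (1.01 log units; beyond the scatter). The size of this step did not carry over from one core to the other, so the earlier step would have been a poor guide to it: the same change on two cores in this assay, a 1.4-fold lower number (0.16 log units; within the scatter) from compound 1 to compound 3 and a 10-fold lower number (1.01 log units; beyond the scatter) from compound 2 to compound 4, 7.1-fold (0.85 log units) apart, beyond the scatter of two such steps. These two pairs show that the effect of this change in this series cannot be assumed to transfer between the two cores, but they do not show what sets the two cores apart, and two pairs establish no general rule for other cores.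

The compounds shown leave open whether an amine or a methoxy group entering at the same place would also give steps that differ between the two cores. They also leave open whether the gap would remain if a hydroxymethyl group stood in place of the chloromethyl group on both cores.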